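A few compounds are considered here, and "the series" means these few. Any claim that something is new, unique, unknown or untested is made for them only; others in the source may bear on it.

Measured so far:
- compound 1 `COc1ccc(NC(=O)/C=C/C(=O)N2C/C(=C\c3ccc([N+](=O)[O-])cc3)C(=O)/C(=C/c3ccc([N+](=O)[O-])cc3)C2)cc1`: 940 nM
- compound 2 `Cc1ccc(NC(=O)/C=C/C(=O)N2C/C(=C\c3ccccc3)C(=O)/C(=C/c3ccccc3)C2)cc1`: 660 nM

Both compounds were measured in a functional assay on Molt4/C8 cells (Homo sapiens) for cytotoxicity; a higher number here means a weaker inhibitor, a lower number a stronger inhibitor. Compound 1, at 940 nM, lies within the usual scatter of compound 2, at 660 nM, so the two values set no order. The pair differs in more than one place, so neither value isolates the effect of any single group.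

The next compound to be measured is compound 3 `Cc1cccc(C)c1NC(=O)/C=C/C(=O)N1C/C(=C\c2ccc([N+](=O)[O-])cc2)C(=O)/C(=C/c2ccc([N+](=O)[O-])cc2)C1`. It keeps the core of compound 1 and carries 2,6-dimethylphenyl in place of 4-methoxyphenyl on an amide-type nitrogen.

Going by the values given here, no measured pair shows this exchange, so the data give no direct guide to its size or direction. Among the compounds with values here, the only guide is that compound 1 at 940 nM and compound 2 at 660 nM sit within the scatter of each other. No step beyond the scatter is therefore expected in this assay, and no direction is favoured with any confidence. The expected change is a 1.2-fold lower number from compound 1 to compound 3 (0.07 log units; within the scatter). Compound 3 is estimated at 800 nM, with an expected range of 300 nM to 2100 nM.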

Compound 3, half-maximal inhibitory concentration: 210 nM
Compound 3: middle estimate off by 3.8-fold (0.58 log units), on the high side, and the stated range ends above it.
By their numbers in this assay, from the lowest: compound 3; then compounds 2 and 1 (each within the scatter of the next).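

Going by these compounds alone, the aryl group on the amide-type nitrogen is the first place where a single exchange can be read: in this assay, 2,6-dimethylphenyl in place of 4-methoxyphenyl gives a 4.5-fold lower number from compound 1 to compound 3 (0.65 log units; beyond the scatter) on an otherwise unchanged core, so this position does register in the cytotoxicity read-out. The exchange keeps the count of heavy atoms and the one six-membered aromatic ring of carbon only, and what differs in the counts is that the entering group has no oxygen and no hydrogen-bond acceptor. Nothing available bears on why the number moves with this exchange.

One step cannot separate the arrival of the two methyl groups from the loss of the methoxy group, and plain phenyl, 2-methylphenyl and 2,6-dichlorophenyl on the same nitrogen would be the comparisons that could pull these apart. On these data alone, it also remains open whether 2,6-dimethylphenyl gives a step of similar size and direction on the core of compound 2, which carries no nitro groups.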